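Phenyl substituent swaps on the benzyl arm

The source may report more compounds than this note shows. Statements on the series, on what has been measured and on what is new or still open speak of the compounds shown alone.

Compound 1 `CCOC(=O)c1ccc(-c2nn(Cc3ccccc3Cl)c3ccccc23)cc1` gives 230 nM in a functional assay on cells (Platelet, Homo sapiens) for inhibition (a lower number here means a stronger inhibitor, a higher number a weaker inhibitor), the lowest of the three numbers, though none of the three stands apart from the others. Compound 2 `CCOC(=O)c1ccc(-c2nn(Cc3cccc(F)c3)c3ccccc23)cc1` gives 270 nM and compound 3 `CCOC(=O)c1ccc(-c2nn(Cc3cccc(OC)c3)c3ccccc23)cc1` gives 260 nM. The steps of a 1.2-fold higher number from compound 1 to compound 2 (0.07 log units; within the scatter) and a 1.1-fold higher number from compound 1 to compound 3 (0.05 log units; within the scatter) show that replacing the 2-chlorophenyl on the saturated chain carbon bound to the aromatic nitrogen has so far left this assay flat; the step of a 1.0-fold lower number from compound 2 to compound 3 (0.02 log units; within the scatter) is flat as well. Compound 4 `CCOC(=O)c1ccc(-c2nn(Cc3ccc(OC)cc3)c3ccccc23)cc1` differs from compound 1 by 4-methoxyphenyl in place of 2-chlorophenyl on a saturated chain carbon bound to an aromatic nitrogen. With every relevant step within the scatter, the expected step is a 1.1-fold higher number from compound 1 to compound 4 (0.05 log units; within the scatter), nothing beyond the scatter. For compound 4 the estimate is 260 nM, with a range from 110 nM to 600 nM.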

Compound 4, half-maximal inhibitory concentration: 620 nM
Beside the measured number, compound 4's estimate is 2.4-fold (0.38 log units) below it; the measured number lies above the stated range.
By their numbers in this assay, from the lowest: compounds 1, 3 and 2 (each within the scatter of the next); then compound 4.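

In this assay this position is not flat after all: 4-methoxyphenyl on the saturated chain carbon bound to the aromatic nitrogen gives steps beyond the scatter against all three earlier groups (a 2.7-fold higher number from compound 1 to compound 4 (0.43 log units; beyond the scatter); a 2.3-fold higher number from compound 2 to compound 4 (0.36 log units; beyond the scatter)). The step between the two methoxyphenyl groups (a 2.4-fold higher number from compound 3 to compound 4 (0.38 log units; beyond the scatter)) shows that the place of the methoxy on the phenyl ring matters, with the group itself unchanged. No data shown here account for this.

Going by these compounds, whether 4-fluorophenyl or 4-chlorophenyl follows compound 4 or stays with compounds 1, 2 and 3 remains open. So does the effect of a carboxylic acid in place of the ethyl ester.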